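Series notes: fluoro to trifluoromethyl step, compound 4 pending

A few compounds are considered here, and "the series" means these few. Any claim that something is new, unique, unknown or untested is made for them only; others in the source may bear on it.

In a functional assay on MCF7 cells (Homo sapiens) for inhibition, read by sulforhodamine B assay (on this read-out higher numbers stand for weaker inhibition of growth and lower numbers for stronger inhibition of growth), the measured compounds stand as follows:
compound 1 `Fc1ccc(-c2ccc(-c3ccc(-c4nc5ccccc5[nH]4)cc3)cc2)cc1` gives 36200 nM
compound 2 `FC(F)(F)c1ccc(-c2ccc(-c3ccc(-c4nc5ccccc5[nH]4)cc3)cc2)cc1` gives 41400 nM
compound 3 `Oc1cccc2[nH]c(-c3ccc(-c4ccc(-c5ccc(F)cc5)cc4)cc3)nc12` gives 3010 nM

Compound 4 `Oc1cccc2[nH]c(-c3ccc(-c4ccc(-c5ccc(C(F)(F)F)cc5)cc4)cc3)nc12` is not yet measured. It differs from compound 3 by trifluoromethyl in place of fluoro on an aromatic carbon. The same change is made between compound 1 and compound 2, (trifluoromethyl in place of fluoro on an aromatic carbon), where it gave a 1.1-fold higher number from compound 1 to compound 2 (0.06 log units; within the scatter). The two cores differ by hydroxy in place of hydrogen on an aromatic carbon; that core change alone gave a 12-fold lower number from compound 1 to compound 3 (1.08 log units; beyond the scatter). Both "place" descriptions read the same, so the change from compound 3 to compound 4 is taken as the same change.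

For compound 4 the expected step is a 1.1-fold higher number from compound 3 to compound 4 (0.05 log units; within the scatter), resting on the step from compound 1 to compound 2 in this assay, a 1.1-fold higher number from compound 1 to compound 2 (0.06 log units; within the scatter), which lay within the scatter. Compound 4 is therefore expected near 3400 nM, estimated between 1500 nM and 8000 nM.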

Compound 4, concentration for 50% growth inhibition: 2310 nM
For compound 4 the middle estimate is 1.5-fold (0.17 log units) above the measured one; the range from low to high includes it.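

In this assay, trifluoromethyl in place of fluoro gives a 1.3-fold lower number from compound 3 to compound 4 (0.11 log units; within the scatter), and this step carries over from one core to the other: the same change on two cores in this assay, a 1.1-fold higher number (0.06 log units; within the scatter) from compound 1 to compound 2 and a 1.3-fold lower number (0.11 log units; within the scatter) from compound 3 to compound 4, 1.5-fold (0.17 log units) apart, within the scatter of two such steps. Hydroxy in place of hydrogen gives an 18-fold lower number from compound 2 to compound 4 (1.25 log units; beyond the scatter), so the large step on the core holds with either group in place: the same change on two cores in this assay, a 12-fold lower number (1.08 log units; beyond the scatter) from compound 1 to compound 3 and an 18-fold lower number (1.25 log units; beyond the scatter) from compound 2 to compound 4, 1.5-fold (0.17 log units) apart, within the scatter of two such steps. This rests on a single pair of cores and a single pair of groups, and because the fluoro to trifluoromethyl step lies within the scatter on both cores, it does not show that a larger step would carry over as well.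

Open, going by these compounds, is how an amine or a carboxylic acid in the same place would behave on either core. Also open, on these data alone, is whether a methoxy in place of the hydroxy would keep the large step.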